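The source may hold more compounds than are shown below. What is called first, only, known or untested is meant among the compounds shown, and "the series" means these compounds.

In a functional assay on ECa-109 cells for antiproliferative activity against ECa-109 cell line (Homo sapiens), read by MTT assay, with a stated time of 48 h (on this read-out higher numbers stand for weaker inhibition and lower numbers for stronger inhibition), compound 1 `COc1ccc(CN(C(=O)CSC2=CN=NC2C)c2cc(OC)c(OC)c(OC)c2)cc1` reaches only a limit of the assay, > 80000 nM. Among the compounds with values here, compound 2 `COc1ccc(CN(C(=O)CSc2nc3ccccc3[nH]2)c2cc(OC)c(OC)c(OC)c2)cc1` gives 42600 nM, the only true number so far. Compound 3 `COc1ccc(CN(C(=O)CSc2nc3ccccc3o2)c2cc(OC)c(OC)c(OC)c2)cc1` differs from it at one place, on a sulfur: 1,3-benzoxazol-2-yl in place of 1H-benzimidazol-2-yl on a sulfur. Within the data shown here, the sole measured step on that sulfur is an at least 1.8-fold lower number from compound 1 to compound 2 (0.27 log units; that floor lies within the scatter), and its floor stays within the scatter. Among the measured compounds shown here, with only that step to go on, no change beyond the scatter is expected in this assay. The expected step is a 1.1-fold higher number from compound 2 to compound 3 (0.02 log units; within the scatter). Compound 3 is estimated at 45000 nM, with an expected range of 18000 nM to 90000 nM.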

Compound 3, half-maximal inhibitory concentration: 24800 nM
The estimate for compound 3 lay 1.8-fold (0.26 log units) above the measured number; measured number inside the range.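

In this assay, 1,3-benzoxazol-2-yl in place of 1H-benzimidazol-2-yl on the sulfur gives a 1.7-fold lower number from compound 2 to compound 3 (0.23 log units; within the scatter), so losing the hydrogen-bond donor at this position produces no change that can be told from the scatter. Replacing the non-aromatic five-membered ring group with 1,3-benzoxazol-2-yl gives an at least 3.2-fold lower number from compound 1 to compound 3 (0.50 log units; beyond the scatter), a floor that, unlike the earlier one, clears the scatter. This size remains only a floor because compound 1 rests on a limit of the assay: the limit of > 80000 nM in this assay, at which 1 of the 3 values shown sits.

On these data alone, whether 1,3-benzothiazol-2-yl or an amine on this sulfur would shift the number beyond the scatter stays open.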